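The source may hold more compounds than are shown below. What is called first, only, known or untested is meant among the compounds shown, and "the series" means these compounds.

Series notes, the step from compound 3 to compound 4.

In an in vitro functional assay on cells for agonist activity at Bombesin receptor subtype-3 (Mus musculus), read by luminescence and calcium flux (on this read-out lower numbers stand for an effect already at smaller amounts and higher numbers for an effect only at larger amounts of compound), compound 1 `CCCCc1cnc(CCc2ccc(-c3ccccc3C(=O)O)cc2)[nH]1` gives 93 nM and compound 2 `N#Cc1ccc(Cc2cnc(CCc3ccc(-c4ccccc4C(=O)O)cc3)[nH]2)cc1` gives 723 nM. Compound 3 `O=C(O)c1ccccc1-c1ccc(CCc2ncc(CCc3ccccc3)[nH]2)cc1` gives 174 nM in this assay and stands second highest of the three numbers: nearest to compound 1, with a 1.9-fold higher number from compound 1 to compound 3 (0.27 log units; within the scatter), and furthest from compound 2, with a 4.2-fold lower number from compound 2 to compound 3 (0.62 log units; beyond the scatter).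

Compound 4 `O=C(O)c1ccccc1-c1ccc(CCc2ncc(Cc3ccc(F)cc3)[nH]2)cc1` differs from compound 3 by 4-fluorophenyl in place of benzyl on a saturated chain carbon bound to an aromatic carbon.

Among the measured compounds shown here, two measured steps bear on this change, both at the same saturated chain carbon bound to an aromatic carbon. Placing a substituted aromatic ring there gave a 7.8-fold higher number from compound 1 to compound 2 (0.89 log units; beyond the scatter), and removing it in favour of benzyl gave a 4.2-fold lower number from compound 2 to compound 3 (0.62 log units; beyond the scatter). For the measured compounds named here, the change from compound 3 to compound 4 runs in the direction of compound 2, so a step towards higher numbers in this assay is expected, smaller than the one to compound 2 because compound 2 gives 723 nM with 4-cyanophenyl rather than the 4-fluorophenyl that enters in compound 4.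

Compound 4 is estimated at 380 nM in this assay, range 130 nM to 1100 nM, a step of a 2.2-fold higher number from compound 3 to compound 4 (0.34 log units; beyond the scatter) that is expected to lie beyond the scatter.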

Compound 4, half-maximal effective concentration: 50 nM
Compound 4: middle estimate off by 7.6-fold (0.88 log units), on the high side; the measured number lies below the stated range.
By their numbers in this assay, from the lowest: compounds 4, 1 and 3 (each within the scatter of the next, the first and the last beyond it); then compound 2.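

With 4-fluorophenyl at this saturated chain carbon bound to an aromatic carbon, this assay shows a 3.5-fold lower number from compound 3 to compound 4 (0.54 log units; beyond the scatter) and so the rise seen with 4-cyanophenyl in compound 2 does not extend to every substituted aromatic ring at this position. Fluoro in place of cyano alone accounts for a 14-fold lower number from compound 2 to compound 4 (1.16 log units; beyond the scatter) and this is the largest step in the series so far, which ties the high number of compound 2 to the cyano-bearing group and not to the aromatic ring as such. Against propyl, the same group gives a 1.9-fold lower number from compound 1 to compound 4 (0.27 log units; within the scatter) and no order can be drawn between the two.

From the compounds shown here alone, whether an unsubstituted phenyl, a methoxy or an amine on the ring in place of fluoro, or a longer chain at this carbon, would stay near compound 4 remains open. Nothing available here explains these steps.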